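The source may report more compounds than this note shows. Statements on the series, on what has been measured and on what is new or still open speak of the compounds shown alone.

Compound 1 (`COc1cc2ncnc(Nc3ccc(F)cc3)c2cc1OCCCCC(=O)Nc1ccc(S(N)(=O)=O)cc1`): 18600 nM
Compound 2 (`COc1cc2ncnc(Nc3ccc(Cl)cc3)c2cc1OCCCCC(=O)Nc1ccc(S(N)(=O)=O)cc1`): 7120 nM

Within the data shown here, in a functional assay on A-431 cells (Homo sapiens) for antiproliferative activity, read by MTT assay, with a stated time of 72 h (a higher number here means a weaker inhibitor, a lower number a stronger inhibitor), compound 2 gives the lower of the two numbers, with compound 1 as its only comparison; the single step available so far is a 2.6-fold lower number from compound 1 to compound 2 (0.42 log units; beyond the scatter). Compound 3 (`COc1cc2ncnc(Nc3ccc(F)c(Br)c3)c2cc1OCCCCC(=O)Nc1ccc(S(N)(=O)=O)cc1`) has not been measured. It differs from compound 2 in one place: 3-bromo-4-fluorophenyl in place of 4-chlorophenyl on a nitrogen on an aromatic ring. The step of a 2.6-fold lower number from compound 1 to compound 2 (0.42 log units; beyond the scatter) bears on this change, since it also exchanged one halogen on an aromatic carbon of the same ring and brought a modest gain. Compound 3 keeps one fluorine and adds one bromine, so a modest further lowering in this assay is expected, of about the same size as the earlier step or smaller, with a real chance that it stays within the scatter. Compound 3 is therefore estimated at 4000 nM (range 1500 nM to 12000 nM), an expected step of a 1.8-fold lower number from compound 2 to compound 3 (0.25 log units; within the scatter).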

Compound 3, half-maximal inhibitory concentration: 8020 nM
Estimate against measurement, compound 3: 2.0-fold (0.30 log units) below, and the stated range covers the measured number.
By their numbers in this assay, from the lowest: compounds 2 and 3 (each within the scatter of the next); then compound 1.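

In this assay, moving from a single chloro to the 3-bromo-4-fluorophenyl group on this nitrogen gives a 1.1-fold higher number from compound 2 to compound 3 (0.05 log units; within the scatter), so the two groups cannot be told apart here. Compound 3 also isolates the effect of adding one halogen: with the fluoro kept, bromo in place of hydrogen gives a 2.3-fold lower number from compound 1 to compound 3 (0.37 log units; beyond the scatter). Among these three compounds, then, the 4-fluorophenyl group of compound 1 gives the highest number, while two different halogen patterns give numbers within the scatter of each other.

Nothing shown here explains these differences. Going by these compounds, it remains open whether a methoxy group or an amine on this phenyl ring, or a shorter chain in place of the present one, would lower the number further.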